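A few compounds are considered here, and "the series" means these few. Any claim that something is new, unique, unknown or untested is made for them only; others in the source may bear on it.

Measured in an ADME assay on cells (Hepatocyte, Mus musculus) for metabolic stability; a lower number here means that the compound disappears faster, a higher number that the compound lasts longer:
- compound 1 `Cc1ccc(C(=O)OC2CCC(CN3CCN(c4cc(=O)c5cc(C(F)(F)F)cc([N+](=O)[O-])c5s4)CC3)CC2)cc1`: 0.202 h
- compound 2 `CC(=O)NC1CCC(CN2CCN(c3cc(=O)c4cc(C(F)(F)F)cc([N+](=O)[O-])c4s3)CC2)CC1`: > 1.55 h (a limit)

Compound 2 stands at > 1.55 h, which is a limit of the assay and not a number. Compound 3 `O=C(OC1CCC(CN2CCN(c3cc(=O)c4cc(C(F)(F)F)cc([N+](=O)[O-])c4s3)CC2)CC1)c1ccc(F)cc1` is not yet measured. It differs from compound 2 by ((4-fluorophenyl)carbonyl)oxy in place of acetamido on a saturated ring carbon, with ((4-fluorophenyl)carbonyl)oxy in place of acetamido on a saturated ring carbon.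

For the measured compounds named here, one measured step bears on this change: an at least 7.6-fold higher number from compound 1 to compound 2 (0.88 log units; beyond the scatter), with acetamido in place of ((4-methylphenyl)carbonyl)oxy on a saturated ring carbon. The change to compound 3 runs the opposite way, from acetamido to a carbonyloxy group. Reading an at least 7.6-fold higher number from compound 1 to compound 2 (0.88 log units; beyond the scatter) backwards, with compound 1 at 0.202 h, a lower number of similar size and beyond the scatter is expected in this assay. The expected step is an at least 6.2-fold lower number from compound 2 to compound 3 (0.79 log units; beyond the scatter). Compound 3 is estimated at 0.25 h, with an expected range of 0.1 h to 0.65 h.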

Compound 3, half-life: 0.0817 h
The estimate for compound 3 lay 3.1-fold (0.49 log units) above the measured number; the measured number lies below the stated range.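

With a second carbonyloxy compound now read, the short half-life on this saturated ring carbon no longer rests on compound 1 alone: in this assay there is an at least 18-fold lower number from compound 2 to compound 3 (1.27 log units; beyond the scatter). The substituent on the aromatic ring of the carbonyloxy group also matters in this assay, with a 2.5-fold lower number from compound 1 to compound 3 (0.39 log units; beyond the scatter), so fluoro in place of methyl on an aromatic carbon moves the number further down rather than leaving it unchanged. The step from the acetamido compound has no fixed size, as compound 2 is held only by a limit of the assay and not a number: the limit of > 1.55 h in this assay, at which 1 of the 3 values shown sits.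

The compounds shown leave open whether the low numbers go with the carbonyloxy link itself or with the aromatic ring it carries. A benzamido group, a plain amine or a hydroxy group on the same ring carbon would separate those two readings.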